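Moving the substituents on the anilide ring of compound 1

A few compounds are considered here, and "the series" means these few. Any claim that something is new, unique, unknown or untested is made for them only; others in the source may bear on it.

Compound 1 `CCc1cccc(NC(=O)CN2CCC(c3cccc[n+]3[O-])CC2)c1` is measured in a functional assay on HEK293 cells for agonist activity at D(4) dopamine receptor (Homo sapiens), read by FLIPR (a higher number here means that more compound is needed for the effect, a lower number that less compound is needed), at 95 nM, the second highest of three numbers. Within the data shown here, compound 2 `CC(C)Oc1cccc(NC(=O)CN2CCC(c3cccc[n+]3[O-])CC2)c1` gives 555 nM, and the step of a 5.8-fold higher number from compound 1 to compound 2 (0.77 log units; beyond the scatter) is the only one within this shared core. Compound 3 `Oc1ccc(N2CCN(Cc3nc4ccccc4[nH]3)CC2)nc1`, a different core, gives 2.4 nM. Compound 4 `Cc1cccc(C)c1NC(=O)CN1CCC(c2cccc[n+]2[O-])CC1` differs from compound 1 by 2,6-dimethylphenyl in place of 3-ethylphenyl on an amide-type nitrogen. Among the measured compounds shown here, no measured step exchanges one substitution pattern of the phenyl ring for another; the step from compound 1 to compound 2 only shows that one change on that ring costs a modest amount. The step of a 2.1-fold higher number from compound 1 to compound 4 (0.32 log units; beyond the scatter) is therefore expected to be small and uncertain in direction. Compound 4 is estimated at 200 nM, with a range from 50 nM to 800 nM.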

Compound 4, half-maximal effective concentration: 346 nM
Beside the measured number, compound 4's estimate is 1.7-fold (0.24 log units) below it; measured number inside the range.
By their numbers in this assay, from the lowest: compound 3; then compound 1; then compounds 4 and 2 (each within the scatter of the next).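

The 3-ethylphenyl and 2,6-dimethylphenyl groups hold the same eight carbons, yet the exchange gives a 3.6-fold higher number from compound 1 to compound 4 (0.56 log units; beyond the scatter), so the arrangement of those carbons on the ring matters, not only their number. Compound 1 now has the lowest number of the three compounds sharing its core, and both measured changes on this ring raise the number. Nothing available here accounts for the shift. Going by these compounds, it remains open whether a phenyl ring carrying a single methyl, a fluorine or an amine would keep or lower the number of compound 1.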